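The source may report more compounds than this note shows. Statements on the series, on what has been measured and on what is new or still open speak of the compounds shown alone.

Measured compounds:
compound 1, `CSc1cnc2ccccc2c1[Se]CC#CCO`: 0.5 ug/mL
compound 2, `CSc1cnc2ccccc2c1[Se]CC#CCCl`: 1.7 ug/mL
compound 3, `OCC#CCSc1cnc2ccccc2c1[Se]CC#CCCl`: 2.6 ug/mL

In a functional assay on CCRF-CEM cells (Homo sapiens) for antiproliferative activity, with a stated time of 72 h (a lower number here means a stronger inhibitor, a higher number a weaker inhibitor), compound 2 holds the second highest of the three numbers. Its nearest neighbour is compound 3, separated by a 1.5-fold higher number from compound 2 to compound 3 (0.18 log units; within the scatter); its furthest is compound 1, separated by a 3.4-fold higher number from compound 1 to compound 2 (0.53 log units; beyond the scatter).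

Compound 4, `CSc1cnc2ccccc2c1SCC#CCO`, has not yet been measured. Relative to compound 2 the change is a group of 6 heavy atoms (4 carbon, 1 oxygen, 1 sulfur; no ring) in place of a group of 6 heavy atoms (4 carbon, 1 chlorine, 1 selenium; no ring), on an aromatic carbon. Part of this change reverses the hydroxy-to-chloro swap seen in a 3.4-fold higher number from compound 1 to compound 2 (0.53 log units; beyond the scatter), which moved the number modestly upward; the remaining part, sulfur entering where selenium leaves, has no measured counterpart among these compounds. The step of a 1.5-fold higher number from compound 2 to compound 3 (0.18 log units; within the scatter) concerns the other side of the core and does not bear on this change.

Compound 4 is therefore expected to show a 2.8-fold lower number from compound 2 to compound 4 (0.45 log units; beyond the scatter), a downward step of roughly the size seen from compound 1 to compound 2, with added uncertainty from the selenium-to-sulfur part. The estimate for compound 4 is 0.6 ug/mL, within a range of 0.2 ug/mL to 2 ug/mL.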

Compound 4, concentration for 50% inhibition: 2.3 ug/mL
Estimate against measurement, compound 4: 3.8-fold (0.58 log units) below; the measured number lies above the stated range.
By their numbers in this assay, from the lowest: compound 1; then compounds 2, 4 and 3 (each within the scatter of the next).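

In this assay, the step of a 4.6-fold higher number from compound 1 to compound 4 (0.66 log units; beyond the scatter) shows that this position, on an aromatic carbon opposite the ring nitrogen, is sensitive to the atom that carries the chain: with the hydroxy end kept, sulfur in place of selenium moves the number beyond the scatter. The step of a 1.4-fold higher number from compound 2 to compound 4 (0.13 log units; within the scatter) shows that the hydroxy end does not by itself keep the number near that of compound 1, and among these compounds only the selenium and hydroxy pairing of compound 1 stands apart from the others. The data shown offer no measurement that accounts for this. As far as these compounds go, it remains open whether a chloro-ended chain on sulfur would sit with compound 2 or compound 4. Also open, from the compounds shown here alone, is how an oxygen link in place of selenium, or an amine or a carboxylic acid at the chain end in place of hydroxy, would read.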